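The source may report more compounds than this note shows. Statements on the series, on what has been measured and on what is new or still open speak of the compounds shown alone.

In a functional assay on isolated protein for antagonist activity at C-C chemokine receptor type 9 (Homo sapiens), read by calcium flux, with a stated time of 10 min (on this read-out lower numbers stand for stronger inhibition and higher numbers for weaker inhibition), compound 2 `CC(C)(C)c1ccc(S(=O)(=O)Nc2ccc(Cl)cc2-c2c(O)ccc[n+]2[O-])cc1` gives 491 nM, and compound 1 `COc1cccnc1-c1cc(Cl)ccc1NS(=O)(=O)c1ccc(C(C)(C)C)cc1` gives 958 nM; the two numbers do not separate, as the step of a 2.0-fold lower number from compound 1 to compound 2 (0.29 log units; within the scatter) shows. Compound 3 `CC(C)(C)c1ccc(S(=O)(=O)Nc2ccc(Cl)cc2-c2ncncc2N)cc1` carries a further exchange at the same aromatic carbon of the shared core: a group of 7 heavy atoms (4 carbon, 3 nitrogen; one six-membered aromatic ring with 2 hetero atoms) in place of a group of 8 heavy atoms (5 carbon, 1 nitrogen, 2 oxygen; one six-membered aromatic ring with 1 hetero atom), on an aromatic carbon, the new ring standing ortho to a large group and meta to a chloro group. For the measured compounds named here, only one measured step bears on this, the exchange of one six-membered aromatic ring for another from compound 1 to compound 2, and it stayed within the scatter. Going by the values given here, there is no measured step with a ring holding two hetero atoms, so the comparison is loose. Compound 3 is therefore expected to give a number close to that of compound 2, with no step beyond the scatter expected in a 1.4-fold higher number from compound 2 to compound 3 (0.15 log units; within the scatter). The estimate for compound 3 in this assay is 700 nM, within 250 nM to 2000 nM.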

Compound 3, half-maximal inhibitory concentration: 3.2 nM
For compound 3 the middle estimate is 220-fold (2.34 log units) above the measured one, outside the stated range (below it).
By their numbers in this assay, from the lowest: compound 3; then compounds 2 and 1 (each within the scatter of the next).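

Compound 1 and compound 2, each with a six-membered aromatic ring holding one hetero atom, lie within the scatter of each other, so the earlier exchange at this aromatic carbon had shown no sensitivity to the ring placed there. In this assay the group of compound 3, on a ring with two hetero atoms, brings a 150-fold lower number from compound 2 to compound 3 (2.19 log units; beyond the scatter) and a 300-fold lower number from compound 1 to compound 3 (2.48 log units; beyond the scatter) at this same carbon, so the position can respond strongly to the group it carries. Nothing measured here accounts for this gain.

Because the ring and the group on it change together, the compounds shown do not separate the contribution of each. On these data alone, how an amine on the ring of compound 1, or a methoxy group on the ring of compound 3, would read remains open.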